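Fluoro in place of chloro, repeated in a second core

The source may hold more compounds than are shown below. What is called first, only, known or untested is meant among the compounds shown, and "the series" means these compounds.

Two pairs in this set share one structural change. Compound 1 `O=C(CSc1nc(Nc2ccccc2)c2ccccc2n1)Nc1ccc(Cl)c(Cl)c1` and compound 2 `O=C(CSc1nc(Nc2ccccc2)c2ccccc2n1)Nc1ccc(F)c(Cl)c1` differ by fluoro in place of chloro on an aromatic carbon. In a functional assay on MDA-MB-231 cells (Homo sapiens) for inhibition, read by MTT assay, with a stated time of 72 h (on this read-out lower numbers stand for stronger inhibition and higher numbers for weaker inhibition), compound 1 gives 14500 nM, and compound 2 gives 21600 nM; the step of a 1.5-fold higher number from compound 1 to compound 2 (0.17 log units; within the scatter) is recorded as within the scatter, so the two values show no difference that can be relied on.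

Compound 3 `C=CC(=O)Nc1cccc(NC(=O)CSc2nc(Nc3ccc(Cl)c(Cl)c3)c3ccccc3n2)c1` carries another core; the difference between the cores of compound 1 and compound 3 is not broken down here. In this assay compound 3 gives 17700 nM, which stands within the scatter of both compound 1 and compound 2, so the three measured values cannot be ordered.

Compound 4 `C=CC(=O)Nc1cccc(NC(=O)CSc2nc(Nc3ccc(F)c(Cl)c3)c3ccccc3n2)c1` is unmeasured and differs from compound 3 by fluoro in place of chloro on an aromatic carbon. The surroundings of the change read the same word for word in both pairs, so this is the same change, now made in the core of compound 3. Among the measured compounds shown here, the only guide to its size is the step from compound 1 to compound 2, which lay within the scatter. The expected step for compound 4 is accordingly small, a 1.2-fold higher number from compound 3 to compound 4 (0.09 log units; within the scatter), resting on compound 2 having given 21600 nM after the same change. Compound 4 is expected to give about 22000 nM in this assay, with an estimated range from 9000 nM to 55000 nM, a span that would leave compound 4 indistinguishable from the three measured compounds.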

Compound 4, half-maximal inhibitory concentration: 10600 nM
The estimate for compound 4 lay 2.1-fold (0.32 log units) above the measured number; the range from low to high includes it.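

In this assay the new step is a 1.7-fold lower number from compound 3 to compound 4 (0.22 log units; within the scatter) and, like the earlier step, it gives no difference that can be relied on, now in the core of compound 3. The two steps point in opposite directions on paper, but they cannot be told apart: the same change on two cores in this assay, a 1.5-fold higher number (0.17 log units; within the scatter) from compound 1 to compound 2 and a 1.7-fold lower number (0.22 log units; within the scatter) from compound 3 to compound 4, 2.5-fold (0.40 log units) apart, within the scatter of two such steps. This shows that the change from 3,4-dichlorophenyl to 3-chloro-4-fluorophenyl gave no readable shift on either of these two cores, so the two results agree to that extent; it does not show that the change has a fixed size, that its direction reverses between the cores, or that the same would hold on any other core in the series.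

The compounds shown leave open whether a group other than fluoro or chloro, such as methoxy, nitrile or an amine, on the aromatic carbon para to the large group would move the number beyond the scatter. Among the compounds shown here, also open is what separates the core of compound 1 from the core of compound 3, as those two compounds differ in more than one place and no single step between them can be read.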